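Moving the fluorine of compound 3

This account rests on a few compounds, and the source may have more. Where it says the series, first, only, none or still open, it means among the compounds named here.

Compounds measured so far in a functional assay on A549 cells (Homo sapiens) for inhibition, read by MTT assay, with a stated time of 48 h (a higher number here means a weaker inhibitor, a lower number a stronger inhibitor), are these:
- compound 1 `COc1ccc2c(=O)c(/C=C/C(=O)Nc3cccc(Cl)c3)coc2c1` gives 470 nM
- compound 2 `COc1cccc(NC(=O)/C=C/c2coc3cc(OC)ccc3c2=O)c1` gives 12800 nM
- compound 3 `COc1ccc2c(=O)c(/C=C/C(=O)NCc3cccc(F)c3)coc2c1` gives 26900 nM

Compound 3 has the highest number of the three, which makes it the weakest inhibitor measured here. Its gap to the nearest compound is modest at a 2.1-fold higher number from compound 2 to compound 3 (0.32 log units; beyond the scatter) and its gap to the furthest is large at a 57-fold higher number from compound 1 to compound 3 (1.76 log units; beyond the scatter) on this scale.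

Compound 4 `COc1ccc2c(=O)c(/C=C/C(=O)NCc3ccc(F)cc3)coc2c1` has the same atoms as compound 3, joined differently, and the change reads 4-fluorophenyl in place of 3-fluorophenyl on a saturated chain carbon bound to an amide-type nitrogen in full. In other words, 3-fluorobenzyl becomes 4-fluorobenzyl.

Among the measured compounds shown here, no measured pair shows a group moving around a ring, so the data offer no direct precedent. The closest guide is a 27-fold higher number from compound 1 to compound 2 (1.44 log units; beyond the scatter) in which one group on the ring was exchanged. That step was large, but it swapped one group for another and did not move the same group, so it serves mainly as a warning to keep the range wide. The expected result is therefore no step beyond the scatter, and no direction is strongly favoured. The estimated change is a 1.2-fold lower number from compound 3 to compound 4 (0.09 log units; within the scatter) in this assay at most a slight shift. For compound 4 the estimated value is 22000 nM with an expected range from 8000 nM to 60000 nM in this test.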

Compound 4, half-maximal inhibitory concentration: > 100000 nM
Compound 4: only a limit was reported; the forecaster's own chance of this, stated with the estimate: 10%; middle value at least 4.5-fold (0.65 log units) away from the limit.
By their numbers in this assay, from the lowest: compound 1; then compound 2; then compound 3. At a limit, above all of these: compound 4.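

In this assay compound 4 gives only a limit of the assay and not a number: the limit of > 100000 nM in this assay, at which 1 of the 4 values shown sits. Among the compounds shown here, compounds 3 and 4 hold the same atoms and differ only in where the fluorine sits on the benzyl ring, yet that move alone gives an at least 3.7-fold higher number from compound 3 to compound 4 (0.57 log units; beyond the scatter), so on this series the place of a single fluorine can matter as much as a change of group, which no earlier pair could show. Compound 4 also stands further from the compounds with a ring directly on the amide-type nitrogen, with an at least 7.8-fold higher number from compound 2 to compound 4 (0.89 log units; beyond the scatter) and an at least 210-fold higher number from compound 1 to compound 4 (2.32 log units; beyond the scatter), making it the weakest inhibitor of the four.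

As far as these compounds go, because compound 4 rests on a limit, these steps have a floor but no known size, and it stays open whether moving a group around the ring has a like effect when the ring sits directly on the amide-type nitrogen, as in compound 1. From the compounds shown here alone, it is also open how the 4-fluorobenzyl compound would compare with versions carrying an amine or a carboxylic acid in place of the fluorine.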